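This account rests on a few compounds, and the source may have more. Where it says the series, first, only, none or still open, it means among the compounds named here.

Of the compounds shown here, three built on one shared core have been tested in a functional assay on ECa-109 cells for inhibition, with ECa-109 cell line (Homo sapiens) as the target, read by sulforhodamine B assay; a higher number here means a weaker inhibitor, a lower number a stronger inhibitor. Compound 1 `O=C1C(Nc2ccccc2)=CC(=O)c2c1nc1n2[C@H]2OC[C@@H](O)[C@H]2OC1` carries a phenyl on an amine nitrogen, and in this assay compound 1 gives 3560 nM. Compound 2 `O=C1C(NC2CCCC2)=CC(=O)c2c1nc1n2[C@H]2OC[C@@H](O)[C@H]2OC1` has a cyclopentyl in place of phenyl on an amine nitrogen. For compound 2 this assay reports only a limit, > 16000 nM. The step from compound 1 to compound 2 is an at least 4.4-fold higher number from compound 1 to compound 2 (0.65 log units; beyond the scatter). Compound 3 `O=C1C=C(NC2CCCCC2)C(=O)c2c1nc1n2[C@H]2OC[C@@H](O)[C@H]2OC1` carries a cyclohexylamino group instead. For compound 3 this assay again reports only a limit, > 16000 nM. Compound 3 thus sits at the limit of > 16000 nM in this assay, at which 2 of the 3 values shown sit, among the weaker compounds shown, with no number of its own.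

Compound 4 `O=C1C=C(N2CCCCC2)C(=O)c2c1nc1n2[C@H]2OC[C@@H](O)[C@H]2OC1` differs from compound 3 in one place: piperidin-1-yl in place of cyclohexylamino on a double-bonded ring carbon. Among the compounds with values here, no measured step covers this exact change. The nearest guide is an at least 4.4-fold higher number from compound 1 to compound 2 (0.65 log units; beyond the scatter), which shows that a ring without aromatic character on the amine nitrogen weakened inhibition. With compound 3 already at the limit, the step from compound 3 to compound 4 is expected to be a step that the limit leaves unreadable from compound 3 to compound 4. Compound 4 is estimated at 25000 nM, with a range from 8000 nM to 80000 nM, and most likely only a limit will again be reported.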

Compound 4, half-maximal inhibitory concentration: > 8000 nM
Compound 4 ended at the assay's limit (the forecaster's own chance of this, stated with the estimate: 70%); the middle value does not contradict the limit.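

Compound 3 and compound 4 are both reported only as limits in this assay, and the step between them cannot be read. The compounds shown leave open how strongly either one inhibits, and whether piperidin-1-yl in place of cyclohexylamino changes inhibition at all.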